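Propargylamine in place of isopropylamine on an indole methylamine

The source may report more compounds than this note shows. Statements on the series, on what has been measured and on what is new or still open speak of the compounds shown alone.

Measured compounds:
compound 1 `CC(C)NCc1cn(Cc2ccccc2)c2ccccc12`, 438000 nM
compound 2 `CC#CCN(C)Cc1cc2cc(OC)ccc2n1C`, 370 nM
compound 3 `CC#CCN(C)Cc1cc2cc(O)ccc2n1C`, 8800 nM

In an assay on isolated protein for inhibition of Amine oxidase [flavin-containing] B (Rattus norvegicus) (a lower number here means a stronger inhibitor, a higher number a weaker inhibitor), compound 1 gives the highest of the three numbers: compound 3 sits far lower, and compound 2 lower still. Within the data shown here, the one step recorded within the set, a 24-fold higher number from compound 2 to compound 3 (1.38 log units; beyond the scatter), concerns a change on an oxygen of the aromatic ring and does not touch the amine. Compound 4 `C#CCN(C)Cc1cn(Cc2ccccc2)c2ccccc12` differs from compound 1 by methyl(propargyl)amino in place of isopropylamino on a saturated chain carbon bound to an aromatic carbon. Among the measured compounds shown here, no measured step addresses this change directly. What the set does show is that compound 2 and compound 3, each carrying a tertiary amine with a triple bond on its chain, give much lower numbers in this assay than compound 1, which carries a secondary amine and no triple bond; the cores differ as well, so this is a pointer rather than a measured step. On that basis compound 4 is expected to move far down, with a 2200-fold lower number from compound 1 to compound 4 (3.34 log units; beyond the scatter) as the estimated step. The estimate for compound 4 is 200 nM, within a range from 20 nM to 3000 nM.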

Compound 4, inhibition constant: 476000 nM
Compound 4: the middle estimate sits 2400-fold (3.38 log units) below what was measured, and the stated range ends below it.
By their numbers in this assay, from the lowest: compound 2; then compound 3; then compounds 1 and 4 (each within the scatter of the next).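

In this assay, replacing isopropylamino with methyl(propargyl)amino on a saturated chain carbon bound to an aromatic carbon gives a 1.1-fold higher number from compound 1 to compound 4 (0.04 log units; within the scatter), so on the core of compound 1 this exchange has no effect that can be told from the scatter. Among these compounds, the earlier compounds could not show this, since compound 1 was the only one with this core and the amine was never varied while the core stayed fixed; this pair does so, and it shows that on this core neither the entering triple bond nor the tertiary amine, taken together with the loss of the hydrogen-bond donor counted in the change, lowers the number. No evidence is available that accounts for this result.

Going by these compounds, it remains open whether the same exchange would also leave the number unchanged on the core of compound 2, where the effect of the amine could differ. Also open, on these data alone, is what a primary amine, or a propargylamino group without the methyl, would give on a saturated chain carbon bound to an aromatic carbon in the core of compound 1.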